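The compounds below may be only part of what the source reports. "The series", "measured", "known", "first", "only" and "open" are said of these compounds alone.

In an ADME assay on MT4 cells (Homo sapiens) for cytotoxicity, read by MTT assay, with a stated time of 96 h (a higher number here means that more compound is tolerated, a lower number that less compound is tolerated), compound 1 `NS(=O)(=O)c1ccc(N2N=C(c3ccc(Oc4ccccc4)cc3)CC2c2ccccc2)cc1` gives 42000 nM, compound 2 `NS(=O)(=O)c1ccc(N2N=C(c3ccc(OCc4ccccc4)cc3)CC2c2ccccc2Cl)cc1` gives 26000 nM and compound 3 `NS(=O)(=O)c1ccc(N2N=C(c3ccc(OCc4ccccc4)cc3)CC2c2ccccc2F)cc1` gives 39000 nM, which places compound 1 within the scatter of both others. Compound 4 `NS(=O)(=O)c1ccc(N2N=C(c3ccc(Oc4ccccc4)cc3)CC2c2cccc(Cl)c2)cc1` departs from compound 1 through (chloro in place of hydrogen on an aromatic carbon), with chloro in place of hydrogen on an aromatic carbon, turning phenyl to 3-chlorophenyl. Among the compounds with values here, the only measured step involving chloro is a 1.5-fold higher number from compound 2 to compound 3 (0.18 log units; within the scatter), which exchanges it for fluoro, and no step from hydrogen to chloro has been measured. That step offers only weak guidance, so no change beyond the scatter is expected, and the estimated step is a 1.3-fold lower number from compound 1 to compound 4 (0.12 log units; within the scatter). For compound 4, the expected value is 32000 nM, with an estimated range from 16000 nM to 62000 nM.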

Compound 4, half-maximal cytotoxic concentration: 8000 nM
Estimate against measurement, compound 4: 4.0-fold (0.60 log units) above; measured number outside the range, below it.
By their numbers in this assay, from the lowest: compound 4; then compounds 2, 3 and 1 (each within the scatter of the next).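

In this assay, chloro in place of hydrogen on this aromatic carbon, turning phenyl to 3-chlorophenyl, gives a 5.3-fold lower number from compound 1 to compound 4 (0.72 log units; beyond the scatter), the first step among these compounds to lie beyond the scatter. Within the data shown here, the only earlier step, a 1.5-fold higher number from compound 2 to compound 3 (0.18 log units; within the scatter), exchanged one halogen for another and showed no such change. Nothing measured here explains the fall in the tolerated concentration.

Going by these compounds, whether the fall belongs to chloro itself or to this place on the ring remains open. Fluoro, methoxy or an amine at the same carbon could separate these two readings.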